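The compounds below may be only part of what the source reports. "The series", "measured", "known", "first", "only" and "open" are said of these compounds alone.

Of the compounds shown here, three built on one shared core have been measured in a functional assay on MIA PaCa-2 cells (Homo sapiens) for antiproliferative activity, read by MTT assay, with a stated time of 72 h; a lower number here means that less compound is needed, a higher number that more compound is needed for the effect. Compound 1 `Cc1nn(Cc2cccc(C(N)=O)c2)c(C)c1NC(=O)c1ccc(COc2ccccc2)cc1` gives 9200 nM in this assay, compound 2 `CCNC(=O)c1cccc(Cn2nc(C)c(NC(=O)c3ccc(COc4ccccc4)cc3)c2C)c1` gives 11000 nM, and compound 3 `CNC(=O)c1cccc(Cn2nc(C)c(NC(=O)c3ccc(COc4cccc(C)c4)cc3)c2C)c1` gives 6200 nM. For the measured compounds named here, the only step between two compounds that differ in a single place, a 1.2-fold higher number from compound 1 to compound 2 (0.08 log units; within the scatter), lies within the scatter. Compound 3 shows the lowest of the three numbers, yet its gaps to compound 1 and to compound 2 are both within the scatter, so the three cannot be put in any order.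

Compound 4 `CNC(=O)c1cccc(Cn2nc(C)c(NC(=O)c3ccc(COc4ccc(C(F)(F)F)cc4C)cc3)c2C)c1` has not yet been measured. It differs from compound 3 by 2-methyl-4-(trifluoromethyl)phenyl in place of 3-methylphenyl on an oxygen on a saturated carbon. Going by the values given here, no measured step bears directly on the group carried by that oxygen: compound 1 and compound 3 differ there and on an amide-type nitrogen at once, and their two values sit within the scatter of each other. With nothing in the data pointing in either direction, the step of a 1.0-fold lower number from compound 3 to compound 4 (0.01 log units; within the scatter) is expected to stay within the scatter. Compound 4 is therefore estimated at 6000 nM, with a likely range from 2500 nM to 15000 nM.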

Compound 4, half-maximal effective concentration: 620 nM
Compound 4: the middle estimate sits 9.7-fold (0.99 log units) above what was measured; the whole stated range lies above it.
By their numbers in this assay, from the lowest: compound 4; then compounds 3, 1 and 2 (each within the scatter of the next).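

For the compounds shown here, the group on the oxygen on a saturated carbon clearly matters in this assay: 2-methyl-4-(trifluoromethyl)phenyl in place of 3-methylphenyl gives a 10-fold lower number from compound 3 to compound 4 (1.00 log units; beyond the scatter), the first single change in this set that lies beyond the scatter. Going by these compounds alone, the earlier compounds showed no such response, as the only step among them, a change on an amide-type nitrogen, stayed within the scatter. No measurement available here accounts for the size of this step.

The compounds shown leave open which part of the new group carries the step, the trifluoromethyl or the methyl in its new place. Going by these compounds, it also remains open how a nitrile, a carboxylic acid or an amine would fare on the same phenyl ring.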